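The source may hold more compounds than are shown below. What is called first, only, known or untested is meant among the compounds shown, and "the series" means these compounds.

In an ADME assay on microsomes from liver (Mus musculus) for metabolic stability, read by LC-MS, with NADPH named in the record, with a stated time of 60 min, tested at 1 uM, in the absence of a further agent (a higher number here means that more of the compound is left, a lower number that less of the compound is left), compound 1 (`COc1ccc(-c2c(C)nc3c(N4CCCC4)cc(C)nn23)cc1OC`) gives > 95%, which is a limit of the assay and not a number. Compound 2 (`COc1ccc(-c2c(C)nc3c(N4CCN(C(=O)OC(C)(C)C)CC4)cc(C)nn23)cc1OC`) gives > 95% in this assay, and this too is a limit. Compound 2 therefore has no exact reading, and the two compounds together offer only (the limit of > 95% in this assay, at which 2 of the 2 values shown sit).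

Compound 3 (`COc1ccc(-c2c(C)nc3c(N4CCN(C(C)=O)CC4)cc(C)nn23)cc1OC`) departs from compound 2 in a single place: methyl in place of tert-butoxy on a carbonyl carbon. In words, this is methyl in place of tert-butoxy on a carbonyl carbon, so that tert-butoxycarbonyl gives way to acetyl. Among the measured compounds shown here, no measured step between two compounds is available to size this change directly. The expectation therefore rests on compound 2, whose reading of > 95% is a limit. The expected change is a number no higher from compound 2 to compound 3 (the limit leaves the size open), and it is expected to stay within the usual scatter of this assay, with no firm direction, though a limit leaves more room for a fall than for a rise. Compound 3 is estimated at 95%, with an expected range from 82% to 100%.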

Compound 3, percent of the compound remaining: > 95%
Compound 3: no number, only a limit; the forecaster's own chance of this, stated with the estimate: 50%; the middle value lies on the limit itself.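

In this assay compound 3 gives > 95%, which is a limit of the assay and not a number. No step from compound 1 or compound 2 to compound 3 can be read, because the readings are all limits: the limit of > 95% in this assay, at which 3 of the 3 values shown sit.

The compounds shown leave open how far compound 1, compound 2 and compound 3 differ in this assay.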